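Swapping chloro for methoxy on compound 2

A few compounds are considered here, and "the series" means these few. Any claim that something is new, unique, unknown or untested is made for them only; others in the source may bear on it.

Compound 1 (`COC(=O)CNc1cc(CS(=O)(=O)/C=C/c2c(OC)cc(OC)cc2OC)ccc1OC`) has a hydrogen on the saturated chain carbon where compound 2 (`COC(=O)C(Nc1cc(CS(=O)(=O)/C=C/c2c(OC)cc(OC)cc2OC)ccc1OC)c1ccc(Cl)cc1`) carries a 4-chlorophenyl group. In a functional assay on K562 cells (Homo sapiens) for cytotoxicity, read by trypan blue exclusion, with a stated time of 96 h (a higher number here means a weaker inhibitor, a lower number a stronger inhibitor), compound 1 gives 100 nM and compound 2 gives 200 nM on the same read-out. Compound 2 therefore stands within the scatter of compound 1, and the two numbers cannot be told apart.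

Compound 3 (`COC(=O)C(Nc1cc(CS(=O)(=O)/C=C/c2c(OC)cc(OC)cc2OC)ccc1OC)c1ccc(OC)cc1`) differs from compound 2 in one place, with methoxy in place of chloro on an aromatic carbon, turning 4-chlorophenyl into 4-methoxyphenyl. Going by the values given here, only one measured step bears on this, and it is indirect: a 2.0-fold higher number from compound 1 to compound 2 (0.30 log units; within the scatter) stayed within the scatter even though a whole 4-chlorophenyl group was added. Among the compounds with values here, no measured compound yet varies the group being swapped here, so this evidence is thin. In this assay no change beyond the scatter is therefore expected, and the expected step is no change at the digits printed from compound 2 to compound 3 (within the scatter) at most a small one. For compound 3 the estimated value is 200 nM with an expected range from 80 nM to 500 nM in this assay.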

Compound 3, half-maximal inhibitory concentration: 150 nM
The estimate for compound 3 lay 1.3-fold (0.12 log units) above the measured number, within the range that was stated.
By their numbers in this assay, from the lowest: compounds 1, 3 and 2 (each within the scatter of the next).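

Going by these compounds alone, this is the first direct test of the group on the aromatic carbon of the 4-chlorophenyl ring: in this assay, methoxy in place of chloro gives a 1.3-fold lower number from compound 2 to compound 3 (0.12 log units; within the scatter), so the two compounds cannot be told apart on this read-out. Methoxy brings one more heavy atom and one hydrogen-bond acceptor that chloro lacks, yet that difference leaves no measurable mark here. The second step, a 1.5-fold higher number from compound 1 to compound 3 (0.18 log units; within the scatter), shows that 4-methoxyphenyl on the saturated chain carbon, like 4-chlorophenyl in compound 2, gives a number that cannot be separated from that of compound 1, which carries only hydrogen there, and nothing measured alongside these numbers offers a reason why they stay so close.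

What the compounds shown leave open is how far this tolerance extends, as only chloro and methoxy have been compared on this ring carbon, and an amine or a carboxylic acid there could behave differently. A plain phenyl ring or a longer chain on the saturated chain carbon also remains an open case, so the flat picture rests on three closely related compounds.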